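This account rests on a few compounds, and the source may have more. Where it says the series, first, only, none or still open, it means among the compounds named here.

Compound 1, `CC#CCn1c(N2CCC[C@@H](N)C2)nc2c1c(=O)n(Cc1ccccc1C(=O)O)c(=O)n2C`: in an ADME assay on isolated protein for inhibition of Dipeptidyl peptidase 9 (Homo sapiens), with stated times of 15 min, 60 s and 20 min (a lower number here means a stronger inhibitor, a higher number a weaker inhibitor), compound 1 gives > 100000 nM, which is a limit of the assay and not a number.
Compound 2, `CC#CCn1c(N2CCC[C@@H](N)C2)nc2c1c(=O)n(Cc1ccc(Br)cc1C(=O)OCC)c(=O)n2C`: in this assay compound 2 gives > 100000 nM, again a limit.
Compound 3, `CC#CCn1c(N2CCC[C@@H](N)C2)nc2c1c(=O)n(Cc1cc(Br)ccc1C(=O)O)c(=O)n2C`: in this assay compound 3 gives > 100000 nM, also a limit.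

All three measured values sit at the same place, (the limit of > 100000 nM in this assay, at which 3 of the 3 values shown sit). Compound 3 therefore stands at the limit alongside the other two, and nothing tells how far beyond it any of them lies. The steps between the measured compounds, a step that the two limits leave unreadable from compound 1 to compound 2, a step that the two limits leave unreadable from compound 1 to compound 3 and a step that the two limits leave unreadable from compound 2 to compound 3, each join two limits, so their size stays hidden.

Compound 4, `CC#CCn1c(N2CCC[C@@H](N)C2)nc2c1c(=O)n(Cc1ccc(Br)cc1C(=O)O)c(=O)n2C`, is not yet measured. It differs from compound 3 by 4-bromo-2-carboxyphenyl in place of 5-bromo-2-carboxyphenyl on a saturated chain carbon bound to an aromatic nitrogen. Among the compounds with values here, none of the measured steps bears on this change with a readable size, so no direction can be drawn from them; the shared core and the rest of the molecule are unchanged. Within the data shown here, the expected step is a step that the limit leaves unreadable from compound 3 to compound 4, that is, no step that can be told apart from the scatter. For compound 4 the estimate in this assay is 150000 nM, with a range from 30000 nM to 1000000 nM, and the result is expected most likely to be reported once more as a limit rather than a number.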

Compound 4, half-maximal inhibitory concentration: > 100000 nM
Compound 4 ended at the assay's limit (the forecaster's own chance of this, stated with the estimate: 85%); the middle value does not contradict the limit.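

Compound 4 ends up where compound 1, compound 2 and compound 3 already stand, so no step among these four compounds can be read: the limit of > 100000 nM in this assay, at which 4 of the 4 values shown sit.

From the compounds shown here alone, how far beyond that limit each compound lies in this assay stays open, and so does whether the bromo, its place on the ring or the ethyl group makes any difference.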